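Trading an Ethenyl Side Group for a Tetrahydronaphthalenyl One

The source may report more compounds than this note shows. Statements on the series, on what has been measured and on what is new or still open speak of the compounds shown alone.

In a functional assay on cells (T-cell line, Homo sapiens) for inhibition (on this read-out lower numbers stand for stronger inhibition and higher numbers for weaker inhibition), compound 1 `CN1CCC(COC(c2ccccc2)c2ccccc2)CC1` gives > 20000 nM, and this value is a limit of the assay. Compound 2 `Cc1ccc(CCCN2CCC(COC(c3ccccc3)c3ccccc3)CC2)cc1` gives 200 nM. Compound 3 `COc1ccc(/C=C/CN2CCC(COC(c3ccccc3)c3ccccc3)CC2)cc1` gives 4300 nM, the higher of the two actual numbers in the series. The gap between them is a 22-fold higher number from compound 2 to compound 3 (1.33 log units; beyond the scatter).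

The next member is compound 4 `c1ccc(C(OCC2CCN(CC3CCc4ccccc4C3)CC2)c2ccccc2)cc1`, where 1,2,3,4-tetrahydronaphthalen-2-yl stands in place of 2-(4-methoxyphenyl)ethenyl on a saturated chain carbon bound to an amine nitrogen in a ring (1,2,3,4-tetrahydronaphthalen-2-yl in place of 2-(4-methoxyphenyl)ethenyl on a saturated chain carbon bound to an amine nitrogen in a ring).

Going by the values given here, three measured steps bear on this change. Substitution at the same place gave an at least 100-fold lower number from compound 1 to compound 2 (2.00 log units; beyond the scatter) and also an at least 4.6-fold lower number from compound 1 to compound 3 (0.66 log units; beyond the scatter). Among the compounds with values here, both of these rest on (the limit of > 20000 nM in this assay, at which 1 of the 3 values shown sits), so they show only that such groups can lower the number. The closest guide is a 22-fold higher number from compound 2 to compound 3 (1.33 log units; beyond the scatter), since compound 2, like compound 4, has no double bond outside aromatic rings. The new group differs from that of compound 2, so only part of that gap is expected to be recovered. The expected change in this assay is therefore a moderate move to a lower number, estimated as a 4.3-fold lower number from compound 3 to compound 4 (0.63 log units; beyond the scatter). For compound 4 the estimated value is 1000 nM, with an expected range from 220 nM to 4500 nM.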

Compound 4, half-maximal inhibitory concentration: 5600 nM
For compound 4 the middle estimate is 5.6-fold (0.75 log units) below the measured one; the whole stated range lies below it.
By their numbers in this assay, from the lowest: compound 2; then compounds 3 and 4 (each within the scatter of the next). At a limit, above all of these: compound 1.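

In this assay, the step from the ethenyl side group to the tetrahydronaphthalenyl one gives a 1.3-fold higher number from compound 3 to compound 4 (0.11 log units; within the scatter), so these two quite different groups cannot be told apart on this read-out. Compound 4 has no double bond outside aromatic rings, as compound 2 has none, yet the printed step is a 28-fold higher number from compound 2 to compound 4 (1.45 log units; beyond the scatter); the absence of that double bond therefore does not by itself go with the low number of compound 2, and the earlier gap between compound 2 and compound 3 cannot be tied to the double bond alone. The new group also gives an at least 3.5-fold lower number from compound 1 to compound 4 (0.55 log units; beyond the scatter), which shows only that it can lower the number, and this step cannot be sized more closely, the value of compound 1 being a limit: the limit of > 20000 nM in this assay, at which 1 of the 4 values shown sits.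

The compounds shown leave open which feature of 2-(4-methylphenyl)ethyl goes with the low number of compound 2, the open chain or the methyl group. A 2-(4-methoxyphenyl)ethyl group would separate the methoxy group from the double bond, and an unsubstituted 2-phenylethyl group or a longer chain would show how much the methyl group and the chain length each contribute.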